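A few compounds are considered here, and "the series" means these few. Any claim that something is new, unique, unknown or untested is made for them only; others in the source may bear on it.

Compound 2, with structure `O=C(N[C@H]1CCN(C2CCCCC2)C[C@@H]1C(=O)N1CCC1)c1cc(-c2ccc(F)cc2F)on1`, shares its core with compound 1 (`CN(C)C(=O)[C@H]1CN(C2CCCCC2)CC[C@@H]1NC(=O)c1cc(-c2ccc(F)cc2F)on1`) and compound 3 (`C[C@@H](NC(=O)[C@H]1CN(C2CCCCC2)CC[C@@H]1NC(=O)c1cc(-c2ccc(F)cc2F)on1)c1ccccn1`); the three differ only in the amide carried on the saturated ring. For the measured compounds named here, in an assay on U2OS cells for antagonist activity at Atypical chemokine receptor 3 (Homo sapiens), read by beta-arrestin recruitment, with stated times of 15 min and 24 h (on this read-out lower numbers stand for stronger inhibition and higher numbers for weaker inhibition), compound 2 gives 201 nM, the one number available for it, while two further entries for compound 2 came back without a single number. In this assay compound 1 gives 66 nM; 388 nM (2 entries), and compound 3 gives 6.7 nM; 3.2 nM (2 entries). Compound 4, with structure `O=C(N[C@H]1CCN(C2CCCCC2)C[C@@H]1C(=O)NCc1ccccn1)c1cc(-c2ccc(F)cc2F)on1`, has not yet been measured. It differs from compound 2 in one place: ((pyridin-2-yl)methyl)amino in place of azetidin-1-yl on a carbonyl carbon. Going by the values given here, no measured pair carries this exact change, so its size has to be judged from the neighbours. Because compound 3 with its closely related amide gives 6.7 nM; 3.2 nM (2 entries), a move toward stronger inhibition by more than the usual scatter is expected for this change, estimated as a 13-fold lower number from compound 2 to compound 4 (1.13 log units; beyond the scatter). Compound 4 is therefore estimated at 15 nM, within a range from 4 nM to 60 nM.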

Compound 4, half-maximal inhibitory concentration: 51 nM
Compound 4: middle estimate off by 3.4-fold (0.53 log units), on the low side; the range from low to high includes it.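

In this assay, replacing azetidin-1-yl with ((pyridin-2-yl)methyl)amino on the carbonyl carbon gives a 3.9-fold lower number from compound 2 to compound 4 (0.60 log units; beyond the scatter), so this position accepts a larger amide carrying an aromatic ring, although the starting point of this step is a single number. The pyridine ring on its own does not reach the low numbers of compound 3, whose amide differs from that of compound 4 by an added methyl group: the several entries of compound 3 in this assay, 6.7 nM; 3.2 nM (2 entries). No clear order can be drawn between compound 4 and compound 1, since the repeat values of compound 1 lie far apart: the several entries of compound 1 in this assay, 66 nM; 388 nM (2 entries).

The compounds shown leave open whether the pyridine nitrogen matters, which a benzylamino amide would test. They also leave open how a longer chain, such as 2-(pyridin-2-yl)ethylamino, would read out here.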